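This account rests on a few compounds, and the source may have more. Where it says the series, first, only, none or still open, it means among the compounds named here.

Of the compounds shown here, three of one shared core have been measured in a functional assay on A549 cells (Homo sapiens) for cytotoxicity, read by MTT assay, with a stated time of 72 h; a higher number here means a weaker inhibitor, a lower number a stronger inhibitor. Compound 1, `CC1=CC[C@]2(C)[C@@H]([C@@H](OC(=O)c3ccc(O)cc3)C1)[C@](O)(C(C)C)C[C@@H]2O`, gives 83700 nM. Compound 2, `C/C=C(/C)C(=O)O[C@H]1CC(C)=C[C@@H](OC(=O)/C(C)=C\C)[C@@]2(C)CC[C@@](O)(C(C)C)[C@H]12`, gives 2800 nM. Compound 3, `COc1ccc(C(=O)O[C@H]2CC(C)=CC[C@@]3(C)CC[C@@](O)(C(C)C)[C@H]23)cc1`, gives 31900 nM in this assay, which places it second highest among the three numbers: compound 1 lies nearest to it, at a higher number beyond the scatter, and compound 2 lies furthest, at a lower number also beyond the scatter.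

The step now followed leads from compound 3 to compound 4, `CC1=CC[C@@]2(C)CC[C@@](O)(C(C)C)[C@@H]2[C@@H](OC(=O)c2ccc(O)cc2)C1`. The two structures differ in a single place:

hydrogen in place of methyl on an oxygen on an aromatic ring

Within the data shown here, no measured pair in this set isolates this same change, so its size is not known from the data. Compound 1 also carries a 4-hydroxyphenyl ester, but it differs from compound 3 in more than this one place, so only its own value can be compared. Since compound 1 gives 83700 nM and compound 3 gives 31900 nM, a step toward a somewhat higher number in this assay is expected, though one that may well fall within the scatter.

Compound 4 is therefore estimated at 50000 nM in this assay, with a range from 20000 nM to 130000 nM. This estimate means an expected step of a 1.6-fold higher number from compound 3 to compound 4 (0.20 log units; within the scatter).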

Compound 4, half-maximal inhibitory concentration: > 100000 nM
Compound 4: a limit, no number; the forecaster's own chance of this, stated with the estimate: 10%; middle value at least 2.0-fold (0.30 log units) from the limit.
By their numbers in this assay, from the lowest: compound 2; then compound 3; then compound 1. At a limit, above all of these: compound 4.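

In this assay compound 4 gives > 100000 nM, which is a limit of the assay and not a number. Hydrogen in place of methyl on an oxygen on an aromatic ring, the change from 4-methoxyphenyl to 4-hydroxyphenyl, gives an at least 3.1-fold higher number from compound 3 to compound 4 (0.49 log units; beyond the scatter), so in this series the methyl on that oxygen makes a difference that no earlier pair could isolate, and the free hydroxy is the weaker of the two. The other change, hydrogen in place of hydroxy on a saturated ring carbon, gives an at least 1.1-fold higher number from compound 1 to compound 4 (0.07 log units; that floor lies within the scatter), so this pair does not show that the ring hydroxy matters, and both readings rest on a limit: the limit of > 100000 nM in this assay, at which 1 of the 4 values shown sits.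

On these data alone, how far compound 4 lies past its limit remains open, and so does the full size of both steps. Also open, as far as these compounds go, is whether an ethoxy group or a longer chain on that oxygen, or an amine in its place on the aromatic ring, would hold the number of compound 3 or move it in either direction in this assay.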